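Swapping the distal aryl ring on a phenoxyacetic acid scaffold

This account rests on a few compounds, and the source may have more. Where it says the series, first, only, none or still open, it means among the compounds named here.

Compound 2 `O=C(O)COc1ccc(NCc2cccc(-c3ccccc3F)c2)cc1F` gives the lower of the two numbers in a functional assay on CHO cells for agonist activity at Free fatty acid receptor 1 (Homo sapiens), read by FLIPR and calcium flux (on this read-out higher numbers stand for an effect only at larger amounts of compound and lower numbers for an effect already at smaller amounts), with 36.5 nM; compound 1 `CCCOc1cc(C)c(-c2cccc(CNc3ccc(OCC(=O)O)c(F)c3)c2)c(C)c1` sits within the scatter of it at 38.7 nM. Compound 3 `Cc1ccc(-c2cccc(CNc3ccc(OCC(=O)O)c(F)c3)c2)c(Cl)c1` is the next candidate: it differs from compound 2 by 2-chloro-4-methylphenyl in place of 2-fluorophenyl on an aromatic carbon. Within the data shown here, no measured pair isolates this change, so the expected step from compound 2 to compound 3 is a 1.2-fold lower number from compound 2 to compound 3 (0.09 log units; within the scatter), which is judged not to exceed the scatter in either direction. Compound 3 is accordingly expected to give 30 nM in this assay, with a range from 12 nM to 75 nM.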

Compound 3, half-maximal effective concentration: 22.5 nM
Beside the measured number, compound 3's estimate is 1.3-fold (0.12 log units) above it; the measured number falls inside the stated range.
By their numbers in this assay, from the lowest: compounds 3, 2 and 1 (each within the scatter of the next).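

With a 1.6-fold lower number from compound 2 to compound 3 (0.21 log units; within the scatter) in this assay, this aromatic carbon accepts 2-chloro-4-methylphenyl in place of 2-fluorophenyl without a step beyond the scatter. The change swaps fluorine for chlorine and adds a methyl group, so this position holds the larger aryl group with no loss in this read-out. No available evidence accounts for the result. The compounds shown leave open how the chlorine and the methyl group each contribute to this step. They also leave open how a distal ring carrying an amine or a hydroxyl group would read here.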